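The source may hold more compounds than are shown below. What is called first, only, known or untested is meant among the compounds shown, and "the series" means these compounds.

Measured so far in a functional assay on HT-29 cells (Homo sapiens) for antiproliferative activity, read by MTT assay, with a stated time of 72 h, tested at 10 uM; on this read-out higher numbers stand for more inhibition at the one concentration tested (going by the name of the read-out) and lower numbers for less inhibition:
compound 1 `CC(C)C(=O)Nc1cc(Oc2ccc(Nc3nccc4[nH]cc(-c5ccc(F)cc5)c(=O)c34)cc2F)ccn1` gives 83.4%
compound 2 `CC(C)(O)Cn1cc(-c2ccc(F)cc2)c(=O)c2c(Nc3ccc(Oc4ccnc(NC(=O)C5CC5)c4)c(F)c3)nccc21` gives -2.6%
compound 3 `Cn1cc(-c2ccc(F)cc2)c(=O)c2c(Nc3ccc(Oc4ccnc(NC(=O)C5CC5)c4)c(F)c3)nccc21` gives 24.8%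

Compound 1 stands highest of the three numbers; compound 3 lies nearest, lower by an amount beyond the scatter, and compound 2 lies furthest, again beyond the scatter. The next compound in the series is compound 4 `CC(C)(O)C(=O)Nc1cc(Oc2ccc(Nc3nccc4[nH]cc(-c5ccc(F)cc5)c(=O)c34)cc2F)ccn1`. It differs from compound 1 in one place: hydroxy in place of hydrogen on a saturated chain carbon bound to a carbonyl carbon and two saturated chain carbons.

Among the measured compounds shown here, only one measured step exists in this assay, a number 27.4 percentage points higher from compound 2 to compound 3 (beyond the scatter). That step sits on a saturated chain carbon bound to an aromatic nitrogen of the shared core, not on the amide side chain, and it removes a whole 1-hydroxy-1-methylethyl group rather than adding a single hydroxy; it bears on the present change only loosely, showing that a hydroxy-bearing group at one place went with a modestly lower read-out. For the measured compounds named here, no measured pair differs only at the amide side chain, so the expectation is uncertain. A small decrease, within or just beyond the scatter, is expected, a number 13.4 percentage points lower from compound 1 to compound 4 (beyond the scatter). Compound 4 is estimated at 70% in this assay, with a range from 40% to 92%.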

Compound 4, a percentage reported as inhibition, at one concentration (the size of the read-out at that concentration, not a potency): -2.9%
Compound 4: middle estimate off by 72.9 percentage points, on the high side, outside the stated range (below it).
By their numbers in this assay, from the lowest: compounds 4 and 2 (each within the scatter of the next); then compound 3; then compound 1.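

Notes on the amide side chain: in this assay, the change from isopropyl to 1-hydroxy-1-methylethyl gives a number 86.3 percentage points lower from compound 1 to compound 4 (beyond the scatter), the only pair shown that reads this position. This place on the chain is therefore highly sensitive to this change: adding hydroxy to a saturated chain carbon bound to a carbonyl carbon and two saturated chain carbons is enough to remove almost all of the inhibition seen with the parent at the one concentration tested, a far larger shift than a number 27.4 percentage points higher from compound 2 to compound 3 (beyond the scatter) at the other site. No data shown here offer an explanation for the size of this step.

On these data alone, it remains open whether the result is specific to hydroxy or would also follow from a methoxy, an amine or a fluorine on the same carbon. Also unresolved is how a longer chain or a cyclopropyl group at this position would read on the core of compound 1, which carries no substituent on its ring nitrogen.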